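Removing Bromine from the Indole Analogue: Expected Cytotoxicity

A few compounds are considered here, and "the series" means these few. Any claim that something is new, unique, unknown or untested is made for them only; others in the source may bear on it.

Of the compounds shown here, three sharing one core have been tested in a functional assay on K562 cells (Homo sapiens) for cytotoxicity, read by trypan blue exclusion, with a stated time of 96 h; on this read-out lower numbers stand for stronger inhibition and higher numbers for weaker inhibition. Compound 1 `COc1ccc(N/C=C\C(=O)c2cc(OC)c(OC)c(OC)c2Br)cc1O` gives 100 nM in this assay. Compound 2 `COc1cc(C(=O)/C=C\Nc2ccc3[nH]ccc3c2)c(Br)c(OC)c1OC` gives 200 nM in this assay; it differs from compound 1 by 1H-indol-5-yl in place of 3-hydroxy-4-methoxyphenyl on an amine nitrogen, and that change gave a 2.0-fold higher number from compound 1 to compound 2 (0.30 log units; within the scatter). Compound 3 `COc1ccc(N/C=C\C(=O)c2cc(OC)c(OC)c(OC)c2)cc1O` gives 100 nM in this assay; it differs from compound 1 by hydrogen in place of bromo on an aromatic carbon, and that change gave no change at the digits printed from compound 1 to compound 3 (within the scatter). The three numbers all lie within the usual scatter of one another, so none of the three compounds can be called more or less potent than the others.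

Compound 4 `COc1cc(C(=O)/C=C\Nc2ccc3[nH]ccc3c2)cc(OC)c1OC` has not yet been measured. It differs from compound 2 by hydrogen in place of bromo on an aromatic carbon, the same change, at the same place, that was made from compound 1 to compound 3. Compound 4 is expected to give about 200 nM in this assay, plausibly anywhere from 100 nM to 400 nM, because the same change gave no change at the digits printed from compound 1 to compound 3 (within the scatter). The expected step is therefore no change at the digits printed from compound 2 to compound 4 (within the scatter), a flat one, resting on a single earlier example.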

Compound 4, half-maximal inhibitory concentration: 500 nM
Beside the measured number, compound 4's estimate is 2.5-fold (0.40 log units) below it; measured number above the stated range.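

Replacing bromo with hydrogen on the core of compound 2 gave a 2.5-fold higher number from compound 2 to compound 4 (0.40 log units; beyond the scatter) in this assay, so on this core alone the change is a modest loss of potency. Set beside the earlier case, the step does not clearly differ from it: the same change on two cores in this assay, no change at the digits printed (within the scatter) from compound 1 to compound 3 and a 2.5-fold higher number (0.40 log units; beyond the scatter) from compound 2 to compound 4, 2.5-fold (0.40 log units) apart, within the scatter of two such steps This shows that the change can be carried from one core to the other without a clear difference in outcome, but with only two pairs it does not show that the outcome is the same on both, nor that it depends on the core.

A third matched pair, on a core carrying another group on the amine nitrogen, would help to show whether the loss of bromo usually matters little or sometimes matters more. On these data alone, it also remains open how a chloro, fluoro or methyl group in the same place would compare with bromo and hydrogen on either core.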